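Adding a bromine to a weak diaryl urea inhibitor

A few compounds are considered here, and "the series" means these few. Any claim that something is new, unique, unknown or untested is made for them only; others in the source may bear on it.

Measured so far:
compound 1 `O=C(Nc1ccc(Oc2ccc(-c3nccs3)cc2)cc1)Nc1cccc(C(F)(F)F)c1` — 9550 nM
compound 2 `O=C(Nc1ccc(Oc2ccc(-c3nccs3)cc2)cc1)Nc1cc(C(F)(F)F)ccc1Cl` — 8900 nM

In a functional assay on MDA-MB-231 cells (Homo sapiens) for inhibition, read by MTT assay and WST assay, with a stated time of 72 h (on this read-out higher numbers stand for weaker inhibition and lower numbers for stronger inhibition), compound 1 gives 9550 nM, the highest of the two numbers. Compound 2, which carries chloro in place of hydrogen on an aromatic carbon, differs only by a 1.1-fold lower number from compound 1 to compound 2 (0.03 log units; within the scatter). Compound 3 `O=C(Nc1ccc(Oc2ccc(-c3nccs3)cc2)cc1)Nc1cc(Br)cc(C(F)(F)F)c1` is the untested analogue; its change is bromo in place of hydrogen on an aromatic carbon. Going by the values given here, the only step that bears on it, the halogen addition from compound 1 to compound 2, lay within the scatter, so another halogen on the same ring is expected to give no step beyond the scatter, a 1.1-fold lower number from compound 1 to compound 3 (0.05 log units; within the scatter). Compound 3 is therefore estimated at 8500 nM, with a range from 4000 nM to 18000 nM.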

Compound 3, half-maximal inhibitory concentration: 4190 nM
The estimate for compound 3 lay 2.0-fold (0.31 log units) above the measured number, within the range that was stated.
By their numbers in this assay, from the lowest: compound 3; then compounds 2 and 1 (each within the scatter of the next).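

Unlike the chloro addition, bromo meta to a trifluoromethyl group moves the number beyond the scatter (a 2.3-fold lower number from compound 1 to compound 3 (0.36 log units; beyond the scatter)), so a halogen added to this ring does not always leave the result unchanged. The step between the two halogenated compounds is of similar modest size (a 2.1-fold lower number from compound 2 to compound 3 (0.33 log units; beyond the scatter)), but the halogen and its place both differ there, so neither can be singled out. No measurement shown here explains these steps.

On these data alone, whether an amine or a carboxylic acid at the bromo position would give a larger step stays open. So does whether bromo elsewhere on this ring would match this result.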